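Tail flick series: side-chain change from compound 1 to compound 4

The compounds below may be only part of what the source reports. "The series", "measured", "known", "first", "only" and "open" are said of these compounds alone.

Measured so far:
compound 1, `O=C(O)CC[C@H](NC(=O)CN(c1nc(Cl)nc2[nH]cnc12)C1CC1)C(=O)O`, 26.8%
compound 2, `CC(C)C[C@H](NC(=O)CN(c1ncnc2c1ncn2C1CCCCO1)C1CC1)C(=O)OCc1ccccc1`, 26.2%
compound 3, `C[C@@H](O)[C@H](NC(=O)CN(c1ncnc2c1ncn2C1CCCCO1)C1CC1)C(=O)OCc1ccccc1`, 23.6%

In a functional assay on the whole organism (Tail, strain ICR) with Mus musculus as the target, in the tail flick test, with a stated time of 30 min, at a dose of 25 umol/kg by the oral route (on this read-out lower numbers stand for a weaker effect and higher numbers for a stronger effect at the one dose given), compound 1 gives 26.8%. Compound 2 gives 26.2% and compound 3 gives 23.6%; all three values lie within the usual scatter of one another, so no order among them can be read. Among the compounds with values here, the only step between compounds that differ in one place is a number 2.6 percentage points lower from compound 2 to compound 3 (within the scatter), and it concerns a different position on the chain than the change considered here.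

Compound 4 is `NCCCC[C@H](NC(=O)CN(c1nc(Cl)nc2[nH]cnc12)C1CC1)C(=O)O`. It differs from compound 1 by 2-aminoethyl in place of carboxy on a saturated chain carbon, three bonds along the chain from an amide-type nitrogen and a carbonyl carbon. Within the data shown here, no measured step bears on this exchange: the one step that exists, from compound 2 to compound 3, changed another position and stayed within the scatter. Nothing in the data therefore points to a step beyond the scatter in this assay in either direction. The expected step is a number 1.8 percentage points lower from compound 1 to compound 4 (within the scatter). Compound 4 is estimated at 25%, with a range from 10% to 40%.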

Compound 4, a percentage reported as activity, at one dose (the size of the read-out at that dose, not a potency): 31.2%
Estimate against measurement, compound 4: 6.2 percentage points below; low and high end bracket the measured number.
By their numbers in this assay, from the lowest: compounds 3, 2, 1 and 4 (each within the scatter of the next).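

In this assay, within the data shown here, the one exchange read at this position is a number 4.4 percentage points higher from compound 1 to compound 4 (within the scatter), the first step made on the chain of compound 1. On this pair, the carboxy group, read one bond further out as 2-carboxyethyl to 4-aminobutyl, gives way to 2-aminoethyl with no step beyond the scatter, so keeping a carboxylic acid at this place is not needed to stay within the scatter at this dose. No measurement available here bears on the reason for this outcome.

Still open, on these data alone, is whether any group at this place moves the read-out beyond the scatter, for instance a guanidine at the end of the chain or a longer amine chain. Also open, as far as these compounds go, is whether the same exchange reads alike on the core of compound 2.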